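Series notes: chloro in place of methyl, compound 4

The source may report more compounds than this note shows. Statements on the series, on what has been measured and on what is new or still open speak of the compounds shown alone.

compound 1 `NS(=O)(=O)c1ccc(-n2nc(-c3ccc(Cl)cc3)cc2-c2cc(O)ccc2O)cc1` — in a functional assay on cells (Cancer cell lines, Homo sapiens) for cytotoxicity, read by sulforhodamine B assay, with a stated time of 48 h (on this read-out higher numbers stand for weaker inhibition of growth and lower numbers for stronger inhibition of growth), compound 1 gives 17800 nM
compound 2 `O=C1C=CC(=O)C(c2cc(-c3ccc(Cl)cc3)nn2-c2ccccc2)=C1` — in this assay compound 2 gives 65400 nM
compound 3 `Cc1ccc(-c2cc(C3=CC(=O)C=CC3=O)n(-c3ccc(S(N)(=O)=O)cc3)n2)cc1` — in this assay compound 3 gives 65400 nM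

Compound 3 stands level with compound 2 at the digits shown, the two together the highest numbers of the three; compound 1 is furthest from compound 3, its number lower by a margin beyond the scatter. Compound 4 `NS(=O)(=O)c1ccc(-n2nc(-c3ccc(Cl)cc3)cc2C2=CC(=O)C=CC2=O)cc1` is unmeasured and differs from compound 3 by chloro in place of methyl on an aromatic carbon. No measured pair differs in this one place alone, so the size of the step cannot be read from the data; compound 2 and compound 3, which differ elsewhere too, give the same number at the digits shown. In this assay the expected step is a 1.2-fold lower number from compound 3 to compound 4 (0.08 log units; within the scatter), no size beyond the scatter. For compound 4 the estimate in this assay is 55000 nM, range 22000 nM to 110000 nM.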

Compound 4, concentration for 50% growth inhibition: 23700 nM
Compound 4: middle estimate off by 2.3-fold (0.37 log units), on the high side; measured number inside the range.
By their numbers in this assay, from the lowest: compounds 1 and 4 (each within the scatter of the next); then compounds 2 and 3 (each within the scatter of the next).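

In this assay, among the compounds shown here, chloro in place of methyl on an aromatic carbon gives the first single-place step for this position, and it lies beyond the scatter (a 2.8-fold lower number from compound 3 to compound 4 (0.44 log units; beyond the scatter)). Sulfamoyl in place of hydrogen on an aromatic carbon also gives a step beyond the scatter (a 2.8-fold lower number from compound 2 to compound 4 (0.44 log units; beyond the scatter)), whereas the non-aromatic ring in place of the aromatic ring stays within it (a 1.3-fold higher number from compound 1 to compound 4 (0.12 log units; within the scatter)). No measurement available here accounts for these steps. On these data alone, whether a methoxy, trifluoromethyl or amine group at this position would match chloro remains open, as does whether the sulfamoyl step holds with methyl in this position.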